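Swapping the sulfonyl partner for a methylpiperazine ring

This account rests on a few compounds, and the source may have more. Where it says the series, first, only, none or still open, it means among the compounds named here.

Compound 1 `O=C(NCc1ccc(S(=O)(=O)c2ccccc2)cc1)N1CCc2ccncc2C1`: 310 nM
Compound 2 `CC(=O)N1CCC(S(=O)(=O)c2ccc(CNC(=O)N3Cc4ccncc4C3)cc2)CC1`: 83 nM

In an assay on isolated protein for inhibition of Nicotinamide phosphoribosyltransferase (Homo sapiens), read by mass spectrometry, with stated times of 15 min and 30 min (a lower number here means a stronger inhibitor, a higher number a weaker inhibitor), compound 1 gives 310 nM and compound 2 gives 83 nM, so compound 2 holds the lower of the two numbers, and the gap between them lies beyond the usual scatter. Compound 3 `CN1CCN(S(=O)(=O)c2ccc(CNC(=O)N3Cc4ccncc4C3)cc2)CC1` keeps the core of compound 2 but carries 4-methylpiperazin-1-yl in place of 1-acetylpiperidin-4-yl on a sulfonyl sulfur. For the measured compounds named here, no measured pair shows a change of this kind, so the step from compound 2 to compound 3 is expected to be a 1.8-fold higher number from compound 2 to compound 3 (0.26 log units; within the scatter), a modest weakening that may not exceed the scatter. Compound 3 is therefore expected to give about 150 nM, within 40 nM to 600 nM.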

Compound 3, half-maximal inhibitory concentration: 38 nM
Compound 3: middle estimate off by 3.9-fold (0.60 log units), on the high side, and the stated range ends above it.
By their numbers in this assay, from the lowest: compound 3; then compound 2; then compound 1.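

In this assay, putting 4-methylpiperazin-1-yl in place of 1-acetylpiperidin-4-yl on a sulfonyl sulfur gives a 2.2-fold lower number from compound 2 to compound 3 (0.34 log units; beyond the scatter), a modest gain. For the compounds shown here, compound 1 and compound 2 differ in more than one place, so this is the first reading of this position alone, and it shows that the group here can move the number while the rest of the molecule stays fixed. Nothing measured here explains the shift. Still open, from the compounds shown here alone, is how a morpholine ring or an open-chain amine would compare on the same sulfonyl sulfur.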